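The compounds below may be only part of what the source reports. "The series", "measured", "known", "first", "only" and "open" are said of these compounds alone.

Compound 3 `CN1CCN(CCCc2c[nH]c3ccc(-n4cnnc4)cc23)CC1` carries only a methyl on the amine nitrogen in a ring. In an assay on CHO cells for displacement of a labelled ligand from 5-hydroxytryptamine receptor 1D (Homo sapiens) (a lower number here means a stronger inhibitor, a higher number a weaker inhibitor), compound 3 gives 33 nM, the highest of the three measured numbers. Compound 1 `c1cc(CN2CCN(CCCc3c[nH]c4ccc(-n5cnnc5)cc34)CC2)ccn1` gives 0.6 nM and compound 2 `NC(=O)C(c1ccccc1)N1CCN(CCCc2c[nH]c3ccc(-n4cnnc4)cc23)CC1` gives 0.2 nM; each carries a larger group at that nitrogen, and the steps from them to compound 3 are large: a 55-fold higher number from compound 1 to compound 3 (1.74 log units; beyond the scatter) and a 170-fold higher number from compound 2 to compound 3 (2.22 log units; beyond the scatter). Compound 4 `c1ccc(CCCN2CCN(CCCc3c[nH]c4ccc(-n5cnnc5)cc34)CC2)cc1` is the member not yet measured. It differs from compound 3 by phenethyl in place of hydrogen on a saturated chain carbon bound to an amine nitrogen in a ring; read one bond further out, the methyl of compound 3 becomes 3-phenylpropyl. The two measured steps that bear on this change both show that a bare methyl at this nitrogen goes with a far higher number than a larger group there, although neither of those groups is phenethyl, so the exact size for compound 4 is open. A large step downward is nevertheless expected: a 22-fold lower number from compound 3 to compound 4 (1.34 log units; beyond the scatter). Compound 4 is accordingly estimated at 1.5 nM, with a range from 0.4 nM to 8 nM, the next measurement being the test of this expectation.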

Compound 4, half-maximal inhibitory concentration: 4.9 nM
Compound 4: the middle estimate sits 3.3-fold (0.51 log units) below what was measured; measured number inside the range.
By their numbers in this assay, from the lowest: compound 2; then compound 1; then compound 4; then compound 3.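

In this assay, the 3-phenylpropyl group shows that a chain of carbon ending in a phenyl ring, with no hydrogen-bond donor or acceptor, is enough to lower the number relative to the methyl, giving a 6.7-fold lower number from compound 3 to compound 4 (0.83 log units; beyond the scatter). That gain stops short of the other two compounds, with an 8.2-fold higher number from compound 1 to compound 4 (0.91 log units; beyond the scatter) and a 25-fold higher number from compound 2 to compound 4 (1.39 log units; beyond the scatter), so replacing the methyl with a larger group does not by itself bring the number down to the level of compound 1 or compound 2, and the identity of the group on this amine nitrogen matters as well as its presence. Nothing among the data offered here accounts for these differences.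

The compounds shown leave open how the number depends on the length of the chain, since a benzyl group or a longer chain ending in phenyl would separate chain length from the presence of the ring. They also leave open whether a primary amide or a pyridine ring placed on the 3-phenylpropyl chain itself would bring the number closer to those of compound 1 and compound 2.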